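Trimming the amide side chain of an aryl ketone piperazine

This account rests on a few compounds, and the source may have more. Where it says the series, first, only, none or still open, it means among the compounds named here.

Measured compounds:
compound 1, `CCCCCC(=O)c1ccc(OCCCN2CCN(C(=O)[C@@H](C)NC(=O)OC(C)(C)C)CC2)cc1`, 10700 nM
compound 2, `CC(C)(C)OC[C@@H](N)C(=O)N1CCN(CCCOc2ccc(C(=O)C3CC3)cc2)CC1`, 45700 nM

Of the compounds shown here, two have been measured in an assay for binding affinity to histamine H2 receptor (Homo sapiens); a higher number here means a weaker inhibitor, a lower number a stronger inhibitor. Compound 1 gives 10700 nM, while compound 2 gives 45700 nM, the higher of the two numbers, so compound 2 is the weaker inhibitor of the pair and the gap between them is beyond the usual scatter.

The next compound, compound 3, `NCCC(=O)N1CCN(CCCOc2ccc(C(=O)C3CC3)cc2)CC1`, shares its core with compound 2 and differs from it in one place: 2-aminoethyl in place of 1-amino-2-(tert-butoxy)ethyl on a carbonyl carbon. Among the measured compounds shown here, no step between measured compounds of this kind is available, so the effect of the change is not known from the data.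

For the measured compounds named here, with only two weak compounds to go on, compound 3 is expected to remain in the same weak region, and the step of a 1.5-fold lower number from compound 2 to compound 3 (0.18 log units; within the scatter) is expected to be small, toward a somewhat lower number, or none beyond the scatter. Compound 3 is therefore estimated at 30000 nM, with a range from 8000 nM to 120000 nM.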

Compound 3, inhibition constant: 100000 nM
Compound 3: the middle estimate sits 3.3-fold (0.52 log units) below what was measured; the measured number falls inside the stated range.
By their numbers in this assay, from the lowest: compound 1; then compound 2; then compound 3.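

On the carbonyl carbon whose other neighbour is the amide-type nitrogen in a ring, 2-aminoethyl in place of 1-amino-2-(tert-butoxy)ethyl gives a 2.2-fold higher number from compound 2 to compound 3 (0.34 log units; beyond the scatter) in this assay. This single change shows that the number responds to this side chain, and that the smaller 2-aminoethyl group, which has no defined stereocentre, moves the compound toward weaker inhibition, though only modestly. Nothing available explains this step.

On these data alone, it remains open which feature of the departing group matters, since the tert-butoxy group and the stereocentre leave together in this one change. As far as these compounds go, whether a carboxylic acid or a longer chain on this carbonyl carbon would give a lower number in this assay also remains open.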